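Fluoro for chloro in compound 3

The compounds below may be only part of what the source reports. "The series", "measured", "known", "first", "only" and "open" are said of these compounds alone.

In a physicochemical assay for solubility, in phosphate buffer, measured as kinetic solubility, at pH 7.4 (on this read-out higher numbers stand for higher solubility and lower numbers for lower solubility), compound 3 `COc1cccc(Cl)c1-c1nc(CN2CCC(C(=O)NCCCN3C[C@H](C)C[C@H](C)C3)CC2)c(C)o1` gives > 76 ug/mL, which is a limit and not a number. Compound 1 `Cc1oc(-c2c(F)cccc2F)nc1CN1CCC(C(=O)NCCCN2C[C@H](C)C[C@H](C)C2)CC1` gives > 72 ug/mL, also a limit. Compound 2 `Cc1oc(-c2c(Cl)cccc2Br)nc1CN1CCC(C(=O)NCCCN2C[C@H](C)C[C@H](C)C2)CC1` gives > 83 ug/mL, again a limit. None of the three has a readable number, so compound 3 cannot be placed in order against the others.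

Compound 4 `COc1cccc(F)c1-c1nc(CN2CCC(C(=O)NCCCN3C[C@H](C)C[C@H](C)C3)CC2)c(C)o1` carries fluoro in place of chloro on an aromatic carbon, ortho to a large group and meta to a methoxy group (fluoro in place of chloro on an aromatic carbon). Three measured changes on the same aromatic carbons bear on this. Exchanging 2,6-difluorophenyl for 2-chloro-6-methoxyphenyl is a step that the two limits leave unreadable from compound 1 to compound 3. The other two are a step that the two limits leave unreadable from compound 1 to compound 2 and a step that the two limits leave unreadable from compound 2 to compound 3. None of them offers a size to carry over.

Compound 1, which also carries fluoro, stands at the limit of > 72 ug/mL, so compound 4 is expected to report a limit as well. The expected change is an at least 1.0-fold lower number from compound 3 to compound 4 (0.01 log units; that floor lies within the scatter), which should stay within the scatter and have no clear direction. For compound 4 the estimate is 74 ug/mL, with an expected range from 62 ug/mL to 86 ug/mL.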

Compound 4, solubility: > 74 ug/mL
Compound 4 was reported as a limit (the forecaster's own chance of this, stated with the estimate: 90%); the middle value sits exactly at the limit.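

In this assay, going by these compounds alone, compound 4 gives > 74 ug/mL, which is a limit and not a number, so no step from it to compound 1, compound 2 or compound 3 can be read. From the compounds shown here alone, how the solubilities of these four compounds truly compare remains open.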